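Two Close Values and an Untested Isomer

A few compounds are considered here, and "the series" means these few. Any claim that something is new, unique, unknown or untested is made for them only; others in the source may bear on it.

Measured in a functional assay on SGC-7901 cells (Homo sapiens) for cytotoxicity, read by MTT assay, with a stated time of 48 h; on this read-out lower numbers stand for stronger inhibition and higher numbers for weaker inhibition:
- Compound 1 `Cc1ccccc1-c1nnc(SCCn2c([N+](=O)[O-])cnc2C)o1`: 32300 nM
- Compound 2 `Cc1cccc(-c2nnc(SCCn3c([N+](=O)[O-])cnc3C)o2)c1O`: 35900 nM

Within the data shown here, only two values are available so far. Compound 2, at 35900 nM, lies within the scatter of compound 1, at 32300 nM, so the two cannot be ranked. The next compound, compound 3 `Cc1ccc(-c2nnc(SCCn3c([N+](=O)[O-])cnc3C)o2)c(O)c1`, has the same atoms as compound 2, joined differently: 2-hydroxy-4-methylphenyl in place of 2-hydroxy-3-methylphenyl on an aromatic carbon. The new group, 2-hydroxy-4-methylphenyl, replaces 2-hydroxy-3-methylphenyl on an aromatic carbon of a five-membered aromatic ring with 2 nitrogen and 1 oxygen. Among the measured compounds shown here, only one measured step bears on this, and it is a different exchange: a 1.1-fold higher number from compound 1 to compound 2 (0.05 log units; within the scatter). No measured step tests the present exchange directly, so the data give no reason to expect a shift beyond the scatter in this assay. The expected change is small, an estimated 1.1-fold lower number from compound 2 to compound 3 (0.02 log units; within the scatter). Compound 3 is expected at 34000 nM, with an estimated range of 15000 nM to 75000 nM.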

Compound 3, half-maximal inhibitory concentration: 36700 nM
Estimate against measurement, compound 3: 1.1-fold (0.03 log units) below; measured number inside the range.
By their numbers in this assay, from the lowest: compounds 1, 2 and 3 (each within the scatter of the next).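

In this assay the exchange of 2-hydroxy-3-methylphenyl for 2-hydroxy-4-methylphenyl on an aromatic carbon of the five-membered aromatic ring gives a 1.0-fold higher number from compound 2 to compound 3 (0.01 log units; within the scatter) and so shows that this rearrangement of the same atoms leaves the number within the scatter. Against 2-methylphenyl, 2-hydroxy-4-methylphenyl gives a 1.1-fold higher number from compound 1 to compound 3 (0.06 log units; within the scatter) and thus adds a second comparison within the scatter, so the three groups shown at this position cannot be told apart in this assay. No measurement at hand offers an explanation for this result.

From the compounds shown here alone, all three compounds carry a methyl-bearing phenyl group here, so it remains open whether a group of another kind at this position, such as an amine, a carboxylic acid or a longer chain, would give a step beyond the scatter. Going by these compounds, whether an unsubstituted phenyl group would stay within the scatter of these three also remains open.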